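The source may report more compounds than this note shows. Statements on the series, on what has been measured and on what is new or still open speak of the compounds shown alone.

Measured so far:
- compound 1: `CCCS(=O)(=O)Nc1ccc(F)c(C(=O)c2n[nH]c3ncc(-c4cccc(Cl)c4)cc23)c1F`, 40%
- compound 2: `CCCS(=O)(=O)Nc1ccc(F)c(C(=O)c2n[nH]c3ncc(-c4ccc(N(C)C)cc4)cc23)c1F`, 2.5%
- compound 3: `CCCS(=O)(=O)Nc1ccc(F)c(C(=O)c2n[nH]c3ncc(-c4ccc(C)c(C)c4)cc23)c1F`, 20%

In an assay for binding affinity to dual specificity mitogen-activated protein kinase kinase 4 (Homo sapiens), read by KINOMEscan, tested at 100 nM (a higher number here means a weaker effect of the compound at the concentration tested, a lower number a stronger effect), compound 3 stands second highest of the three numbers, with compound 2 nearest and compound 1 furthest. The step of a number 20 percentage points lower from compound 1 to compound 3 (beyond the scatter) and the step of a number 17.5 percentage points higher from compound 2 to compound 3 (beyond the scatter) both turn on the aryl group at the same aromatic carbon.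

Compound 4 is `CCCS(=O)(=O)Nc1ccc(F)c(C(=O)c2n[nH]c3ncc(-c4ccc(C(F)(F)F)cc4)cc23)c1F`. The change: 4-(trifluoromethyl)phenyl in place of 3,4-dimethylphenyl on an aromatic carbon. Within the data shown here, no measured step puts a trifluoromethyl group at this place, so the steps above only frame the range such aryl swaps have given; the halogen-bearing compound 1 gave the highest number so far. A modest upward step is expected, a number 10 percentage points higher from compound 3 to compound 4 (within the scatter). Compound 4 is therefore estimated at 30%, within 10% to 60%.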

Compound 4, a percentage reported as activity, at one concentration (the size of the read-out at that concentration, not a potency): 29%
Estimate against measurement, compound 4: 1 percentage points above; low and high end bracket the measured number.
By their numbers in this assay, from the lowest: compound 2; then compounds 3 and 4 (each within the scatter of the next); then compound 1.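

In this assay, 4-(trifluoromethyl)phenyl and 3,4-dimethylphenyl on this aromatic carbon are not separated (in a number 9 percentage points higher from compound 3 to compound 4 (within the scatter)), so two quite different aryl substituents can give results within the scatter. Trifluoromethyl in place of dimethylamino has a clear effect (a number 26.5 percentage points higher from compound 2 to compound 4 (beyond the scatter)), and compound 4 also separates from the 3-chlorophenyl compound (a number 11 percentage points lower from compound 1 to compound 4 (beyond the scatter)). No measurement shown accounts for these differences.

From the compounds shown here alone, whether the low number of compound 2 is particular to dimethylamino remains open. A morpholine, a methoxy group or a carboxylic acid on the same phenyl ring would test this.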